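A few compounds are considered here, and "the series" means these few. Any claim that something is new, unique, unknown or untested is made for them only; others in the source may bear on it.

Compound 1 `COc1cc(F)c(CN2C(=O)N(c3ccc(OC)c(OC)c3)S(=O)(=O)c3ccccc32)c(Cl)c1`: 0.398 nM
Compound 2 `COc1cc(F)c(CN2C(=O)N(c3cnc(OC)c(OC)c3)S(=O)(=O)c3ccccc32)c(F)c1`: 2.51 nM
Compound 3 `COc1ccc(N2C(=O)N(Cc3c(F)cc(F)cc3Cl)c3ccccc3S2(=O)=O)cc1OC`: 25.1 nM

Among these three, compound 3 gives the highest number in an assay on isolated protein for displacement of a labelled ligand from Orexin/Hypocretin receptor type 1 (Homo sapiens), with a stated time of 90 min (a lower number here means a stronger inhibitor, a higher number a weaker inhibitor), and its gap to each of the other two lies beyond the usual scatter. For the measured compounds named here, the only single-point step that reaches compound 3 is a 63-fold higher number from compound 1 to compound 3 (1.80 log units; beyond the scatter), a change at the benzyl ring, not at the ring that is altered next.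

Compound 4 `COc1cc(N2C(=O)N(Cc3c(F)cc(F)cc3Cl)c3ccccc3S2(=O)=O)cnc1OC` differs from compound 3 in one place: 5,6-dimethoxypyridin-3-yl in place of 3,4-dimethoxyphenyl on an amide-type nitrogen in a ring. Going by the values given here, no measured pair isolates this exchange. Compound 1 and compound 2 differ in two places at once, one of them this same ring exchange, and in this assay compound 1 gives 0.398 nM while compound 2 gives 2.51 nM; that comparison hints at a higher number but cannot separate the two changes. A moderate rise is therefore expected from compound 3 to compound 4, a 2.0-fold higher number from compound 3 to compound 4 (0.30 log units; within the scatter), with wide uncertainty. For compound 4 the estimated value is 50 nM, expected to fall between 15 nM and 160 nM.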

Compound 4, inhibition constant: 39.8 nM
Beside the measured number, compound 4's estimate is 1.3-fold (0.10 log units) above it; low and high end bracket the measured number.
By their numbers in this assay, from the lowest: compound 1; then compound 2; then compounds 3 and 4 (each within the scatter of the next).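

In this assay, 5,6-dimethoxypyridin-3-yl in place of 3,4-dimethoxyphenyl gives a 1.6-fold higher number from compound 3 to compound 4 (0.20 log units; within the scatter), so with the 2-chloro-4,6-difluorobenzyl group in place, this ring exchange has no effect that can be told apart from the scatter. With the 5,6-dimethoxypyridin-3-yl ring held constant, the benzyl exchange gives a 16-fold higher number from compound 2 to compound 4 (1.20 log units; beyond the scatter), so a large step on the benzyl side now appears with both this ring and the 3,4-dimethoxyphenyl ring, where the step was a 63-fold higher number from compound 1 to compound 3 (1.80 log units; beyond the scatter). No supporting information explains either step.

Going by these compounds, whether the ring exchange stays this small when the benzyl ring carries a methoxy group remains open, since compound 1 and compound 2 differ in two places at once. Also open, on these data alone, is how an ethoxy group or a nitrile in place of that methoxy group would read.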